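The source may report more compounds than this note shows. Statements on the series, on what has been measured and on what is new or still open speak of the compounds shown alone.

Measured compounds in the series so far:

- compound 1, `Cc1ccccc1C(=O)N(C)c1ccc(C(O)(C(F)(F)F)C(F)(F)F)cc1`, in an ADME assay on Li23 cells (Homo sapiens) for cytotoxicity, read by WST assay (on this read-out higher numbers stand for lower toxicity in this test and lower numbers for higher toxicity in this test), compound 1 gives 38000 nM
- compound 2, `CN(c1ccc(C(O)(C(F)(F)F)C(F)(F)F)cc1)S(=O)(=O)c1ccccc1`, in this assay compound 2 gives 16000 nM

Among the compounds with values here, compound 2 stands at the lowest of the two numbers; its nearest neighbour is compound 1, and the one measured step runs a 2.4-fold lower number from compound 1 to compound 2 (0.38 log units; beyond the scatter). That step swaps the whole group on the ring nitrogen, so it speaks to the amide-to-sulfonamide exchange and to nothing else.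

Compound 3, `Cc1ccc(S(=O)(=O)N(C)c2ccc(C(O)(C(F)(F)F)C(F)(F)F)cc2)cc1`, is the next compound in the series and is still unmeasured in this assay. It differs from compound 2 by methyl in place of hydrogen on an aromatic carbon. Within the data shown here, no measured step touches the outer phenyl of the sulfonyl group, so the comparison of compound 1 with compound 2 does not bear on this change; there is no direct precedent in the two numbers at hand.

Among the measured compounds shown here, with only a single methyl added on an aromatic carbon and no step of that kind on record, the expectation for compound 3 is a number close to that of compound 2, with no step beyond the scatter: the estimated step is no change at the digits printed from compound 2 to compound 3 (within the scatter). The estimate for compound 3 in this assay is therefore 16000 nM, expected to fall between 7000 nM and 36000 nM.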

Compound 3, half-maximal cytotoxic concentration: 15000 nM
Compound 3: middle estimate off by 1.1-fold (0.03 log units), on the high side; measured number inside the range.
By their numbers in this assay, from the lowest: compounds 3 and 2 (each within the scatter of the next); then compound 1.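

Working notes on the sulfonyl side of the series. In this assay, phenyl to 4-methylphenyl gives a 1.1-fold lower number from compound 2 to compound 3 (0.03 log units; within the scatter), so a methyl in place of hydrogen on this aromatic carbon, para to a large group, leaves the number within the scatter. Within the data shown here, this is the first read on the outer ring of the sulfonyl group: the earlier step, a 2.4-fold lower number from compound 1 to compound 2 (0.38 log units; beyond the scatter), exchanged the whole group on the ring nitrogen and said nothing about substitution on that ring, and it remains the only step beyond the scatter. Nothing on hand explains why the added methyl produces so small a step.

A single small carbon group at a single place does not define what this position accepts, so an amine, a carboxylic acid or a longer chain such as ethyl at the same carbon remains an open case in this assay. All three compounds also keep the methyl on the nitrogen and the shared core, which leaves the contribution of those parts to the read-out open.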